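Amino in Place of Nitro: Forecast for Compound 3

The source may report more compounds than this note shows. Statements on the series, on what has been measured and on what is new or still open speak of the compounds shown alone.

The account concerns two measured compounds and one awaiting its number. Compound 1 `Cn1c(=O)c(S(=O)(=O)c2ccc(F)cc2[N+](=O)[O-])cc2cnc(Nc3ccc4[nH]ccc4c3)nc21` was tested in a functional assay on DU-145 cells (Homo sapiens) for inhibition, read by trypan blue exclusion, with a stated time of 72 h (on this read-out higher numbers stand for weaker inhibition and lower numbers for stronger inhibition), where compound 1 gives 1500 nM. Compound 2 `Cn1c(=O)c(S(=O)(=O)c2ccc(F)cc2F)cc2cnc(Nc3ccc4cccc(O)c4n3)nc21`, which shares the core but differs at more than one place, was tested in the same way, and compound 2 gives 5000 nM. Among the measured compounds shown here, of these two numbers, the one for compound 1 is the lowest, and its distance to the number for compound 2 lies beyond the usual scatter of repeated measurements; since the two compounds differ at several places, no single step can be drawn between them.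

Compound 3 `Cn1c(=O)c(S(=O)(=O)c2ccc(F)cc2N)cc2cnc(Nc3ccc4[nH]ccc4c3)nc21` has not yet been measured in this assay. It differs from compound 1 in one place: amino in place of nitro on an aromatic carbon. For the measured compounds named here, no measured pair shows this change, so its effect is unknown here. For compound 3 the step of a 1.7-fold higher number from compound 1 to compound 3 (0.22 log units; within the scatter) is expected to be small, within the scatter, leaning toward a higher number. Compound 3 is therefore estimated at 2500 nM, with a range from 600 nM to 10000 nM.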

Compound 3, half-maximal inhibitory concentration: 3000 nM
Compound 3: middle estimate off by 1.2-fold (0.08 log units), on the low side, and the stated range covers the measured number.
By their numbers in this assay, from the lowest: compounds 1, 3 and 2 (each within the scatter of the next, the first and the last beyond it).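

In this assay, among the compounds shown here, amino in place of nitro on an aromatic carbon, ortho to a large group and meta to a fluoro group, gives a 2.0-fold higher number from compound 1 to compound 3 (0.30 log units; within the scatter), and this is the first step in the account that isolates a single place. It shows that at this position 3 heavy atoms can give way to 1 heavy atom, with 1 hydrogen-bond donor entering, while the numbers of the two compounds stay within the scatter of each other. Nothing measured on these groups bears on this result, and no reason for it can be given here.

The compounds shown leave open how an acetamide, a methylamino group or a hydroxyl group at this position would read in this assay, as only nitro and amino form a single-place pair here. For the compounds shown here, whether the same exchange also stays within the scatter when the rest of the molecule differs, as it does in compound 2, is open too, and no second pair speaks to it.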